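Swapping isopropylamino for diethylamino on compound 1

This account rests on a few compounds, and the source may have more. Where it says the series, first, only, none or still open, it means among the compounds named here.

Measured in an ADME assay on the whole organism for inhibition, with Oryza sativa as the target, with a stated time of 4 days; a higher number here means a weaker inhibitor, a lower number a stronger inhibitor:
- compound 1 `CC(C)Nc1nc(Cl)nc(N[C@@H](C)c2ccccc2)n1` gives 23400 nM
- compound 2 `CC(C)Nc1nc(Cl)nc(N[C@H](C)c2ccccc2)n1` gives 5370 nM
- compound 3 `CC[C@@H](C)Nc1nc(Cl)nc(N[C@H](C)c2ccccc2)n1` gives 8320 nM

Compound 1 has the highest number of the three, which makes it the weakest inhibitor here. Compound 4 `CCN(CC)c1nc(Cl)nc(N[C@@H](C)c2ccccc2)n1` differs from it in one place: diethylamino in place of isopropylamino on an aromatic carbon. The closest measured change is a 1.5-fold higher number from compound 2 to compound 3 (0.19 log units; within the scatter), within the scatter, where methyl replaces hydrogen on the chain of that same isopropylamino group. The larger 4.4-fold lower number from compound 1 to compound 2 (0.64 log units; beyond the scatter) is purely a change of configuration (the fact that compounds 1 and 2 differ only in the configuration as drawn), and compound 4 keeps the configuration of compound 1. For the measured compounds named here, no measured step swaps isopropylamino for diethylamino, so no step beyond the scatter is expected in this assay. The expected change is a 1.1-fold higher number from compound 1 to compound 4 (0.03 log units; within the scatter). Compound 4 is estimated at 25000 nM, with an expected range of 8000 nM to 80000 nM.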

Compound 4, half-maximal inhibitory concentration: 380 nM
The estimate for compound 4 lay 66-fold (1.82 log units) above the measured number; the whole stated range lies above it.
By their numbers in this assay, from the lowest: compound 4; then compounds 2 and 3 (each within the scatter of the next); then compound 1.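

In this assay, the change of amino group on the aromatic carbon between two ring nitrogen atoms gives a 62-fold lower number from compound 1 to compound 4 (1.79 log units; beyond the scatter). That matters far more than the small chain change from compound 2 to compound 3 suggested. Diethylamino, unlike isopropylamino, carries no hydrogen-bond donor, so replacing the whole group differs from adding a methyl to its chain. Nothing given here explains the size of this step. The compounds shown leave open whether it goes with the extra carbon or with the missing donor, which ethylamino or dimethylamino at this position could help separate. They also leave open whether diethylamino has a similar effect in the configuration of compound 2.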